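Methyl for methoxy on the chloro-bearing core

The compounds below may be only part of what the source reports. "The series", "measured", "known", "first", "only" and "open" are said of these compounds alone.

Compound 1 `COc1ccc(Cn2c(N)nc3cc(Cl)c(Cl)cc32)cc1` is the reference of the set; in a functional assay on KB cells (Homo sapiens) for inhibition (on this read-out higher numbers stand for weaker inhibition and lower numbers for stronger inhibition), compound 1 gives 45000 nM. Compound 2 `Cc1ccc(Cn2c(N)nc3cc(Cl)c(Cl)cc32)cc1` carries methyl in place of methoxy on an aromatic carbon; in this assay compound 2 gives 50000 nM, and the step is a 1.1-fold higher number from compound 1 to compound 2 (0.05 log units; within the scatter). Compound 3 `COc1ccc(Cn2c(Cl)nc3cc(Cl)c(Cl)cc32)cc1` differs from compound 1 in the core by chloro in place of amino on an aromatic carbon. For compound 3 this assay reports only a limit, > 100000 nM (the limit of > 100000 nM in this assay, at which 1 of the 3 values shown sits). The step is an at least 2.2-fold higher number from compound 1 to compound 3 (0.34 log units; beyond the scatter), and with the limit the true size is not known.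

Compound 4 `Cc1ccc(Cn2c(Cl)nc3cc(Cl)c(Cl)cc32)cc1` is not yet measured. Relative to compound 3 it carries methyl in place of methoxy on an aromatic carbon, the same change as from compound 1 to compound 2, at the same place on the ring. The step from compound 3 to compound 4 in this assay is expected to be a step that the limit leaves unreadable from compound 3 to compound 4, because the same change gave a 1.1-fold higher number from compound 1 to compound 2 (0.05 log units; within the scatter). Compound 4 is therefore estimated at 150000 nM in this assay, between 70000 nM and 400000 nM, most probably reported again as a limit rather than a number.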

Compound 4, half-maximal inhibitory concentration: > 100000 nM
Compound 4: only a limit was reported (the forecaster's own chance of this, stated with the estimate: 85%); the middle value is on the limit's open side.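

Compound 4 stands in this assay only as a limit, > 100000 nM, so the step from compound 3 cannot be read, and nothing here shows whether methyl in place of methoxy behaves on the core of compound 3 as it does on the core of compound 1. Within the data shown here, the one readable new step concerns chloro in place of amino, an at least 2.0-fold higher number from compound 2 to compound 4 (0.30 log units; that floor lies within the scatter), and it gives a floor rather than a size. Set beside the methoxy pair, this floor does not measure how far the change carries from one compound pair to the other: the same change on two cores in this assay, an at least 2.2-fold higher number (0.34 log units; beyond the scatter) from compound 1 to compound 3 and an at least 2.0-fold higher number (0.30 log units; that floor lies within the scatter) from compound 2 to compound 4; the limit leaves it open whether they differ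

Still open, going by these compounds, is whether any compound with chloro in place of amino gives a number rather than a limit in this assay. Also open, on these data alone, is how a hydroxyl or a carboxylic acid in place of the methoxy would read, and whether an amide or a longer amine in place of the amino group keeps the values of compound 1 and compound 2.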